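A few compounds are considered here, and "the series" means these few. Any claim that something is new, unique, unknown or untested is made for them only; others in the source may bear on it.

Working notes on the series in an ADME assay on the whole organism (plasma, Macaca fascicularis) for protein binding, read by LC-MS, using equilibrium dialysis and cassette dosing, with a stated time of 24 h, at a dose of 1 mg/kg by the oral route; a lower number here means a smaller unbound share, a higher number a larger unbound share of the compound.

Two compounds carry numbers. Compound 1 (`C[C@H](c1ccc(-c2cc(Cl)ccc2-c2nc(=O)o[nH]2)cc1)N(CC1CC1)c1nc2c(C(=O)O)cccc2o1`) gives 0.000108 in this assay. Compound 2 (`CCCCN(c1nc2c(C(=O)O)cccc2o1)[C@H](C)c1ccc(-c2ccccc2-c2nnn[nH]2)cc1`) gives 0.000285 in this assay. Compound 1 stands lowest of the two; compound 2 sits above it by a margin that falls beyond the scatter, so the two are distinguishable. Within the data shown here, no pair among the measured compounds differs in a single place, so no step of this kind is available to lean on.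

Compound 3 (`C[C@H](c1ccc(-c2ccccc2-c2nc(=O)o[nH]2)cc1)N(CC1CC1)c1nc2c(C(=O)O)cccc2o1`) is the next compound to be run. Relative to compound 1 the change is hydrogen in place of chloro on an aromatic carbon. Nothing in the measured set speaks directly to the removal of a chloro group, so the expectation rests on the value of compound 1 alone. The step from compound 1 to compound 3 is estimated as a 1.8-fold higher number from compound 1 to compound 3 (0.25 log units; within the scatter), a modest rise that may well sit within the scatter. For compound 3 the unbound fraction is estimated at 0.00019, with a range from 0.00009 to 0.00042.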

Compound 3, unbound fraction: 0.0000851
The estimate for compound 3 lay 2.2-fold (0.35 log units) above the measured number, and the stated range ends above it.
By their numbers in this assay, from the lowest: compounds 3 and 1 (each within the scatter of the next); then compound 2.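

Hydrogen in place of chloro, on an aromatic carbon of a six-membered aromatic ring of carbon only, meta to a large group and para to a group of 6 heavy atoms, gives the first single-place step in this assay: a 1.3-fold lower number from compound 1 to compound 3 (0.10 log units; within the scatter). That step lies within the scatter, so this one chlorine atom can be removed from this carbon without a distinguishable shift in the unbound fraction, and the pair cannot be ordered. No accompanying measurement bears on why the two compounds read alike.

On these data alone, this is one exchange at one carbon, so it remains open whether a larger or differently built substituent there, such as a methoxy group or an amine, would also leave the reading within the scatter, and whether the other carbons of this ring would tolerate the same exchange. Compound 2 differs from compound 3 in more than one place, so the contributions of the chain on the nitrogen and of the acidic ring group to this assay remain unseparated.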